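This account rests on a few compounds, and the source may have more. Where it says the series, first, only, none or still open, it means among the compounds named here.

Compound 3, `C[C@H](NC(=O)C(=O)Nc1ccccc1Cc1ccccc1)C(=O)N[C@@H](CC(=O)O)C(=O)COc1c(F)c(F)cc(F)c1F`, carries a benzyl group on an aromatic carbon of the shared core. In a functional assay on THP-1 cells (Homo sapiens) for inhibition (on this read-out lower numbers stand for stronger inhibition and higher numbers for weaker inhibition), compound 3 gives 540 nM, the highest of the two numbers shown. Compound 1, `C[C@H](NC(=O)C(=O)Nc1ccccc1F)C(=O)N[C@@H](CC(=O)O)C(=O)COc1c(F)c(F)cc(F)c1F`, has fluoro at that carbon and gives 160 nM in this assay. Compound 2, `C[C@H](NC(=O)C(=O)Nc1ccccc1-c1ccc[nH]1)C(=O)N[C@@H](CC(=O)O)C(=O)COc1c(F)c(F)cc(F)c1F`, carries 1H-pyrrol-2-yl there. In this assay compound 2 gives > 32000 nM, which is a limit of the assay and not a number. The steps connecting them are a 3.4-fold higher number from compound 1 to compound 3 (0.53 log units; beyond the scatter), an at least 200-fold higher number from compound 1 to compound 2 (2.30 log units; beyond the scatter) and an at least 59-fold lower number from compound 2 to compound 3 (1.77 log units; beyond the scatter). Compound 4, `C[C@H](NC(=O)C(=O)Nc1ccccc1Oc1ccccc1)C(=O)N[C@@H](CC(=O)O)C(=O)COc1c(F)c(F)cc(F)c1F`, has not been measured; it differs from compound 3 by phenoxy in place of benzyl on an aromatic carbon. The step that bears most directly, one large group for another, was an at least 59-fold lower number from compound 2 to compound 3 (1.77 log units; beyond the scatter), whereas a 3.4-fold higher number from compound 1 to compound 3 (0.53 log units; beyond the scatter) was modest. Phenoxy keeps the same atom count as benzyl, so only a small step is expected. In this assay compound 4 is expected near 600 nM, between 200 nM and 2500 nM. That estimate means a 1.1-fold higher number from compound 3 to compound 4 (0.05 log units; within the scatter).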

Compound 4, half-maximal inhibitory concentration: 800 nM
Beside the measured number, compound 4's estimate is 1.3-fold (0.12 log units) below it; the range from low to high includes it.
By their numbers in this assay, from the lowest: compound 1; then compounds 3 and 4 (each within the scatter of the next). At a limit, above all of these: compound 2.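

In this assay, phenoxy in place of benzyl on the aromatic carbon gives a 1.5-fold higher number from compound 3 to compound 4 (0.17 log units; within the scatter), so at this position an oxygen in place of a carbon in the group leaves the read-out unchanged within the scatter. Compound 4 thus joins compound 3 as a second large group that stays measurable, with a 5.0-fold higher number from compound 1 to compound 4 (0.70 log units; beyond the scatter), while an at least 40-fold lower number from compound 2 to compound 4 (1.60 log units; beyond the scatter) sets both apart from the 1H-pyrrol-2-yl group, so group size alone does not account for the loss in compound 2. The value of compound 2 is a limit and not a number, which makes that last step a bound: the limit of > 32000 nM in this assay, at which 1 of the 4 values shown sits.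

Which feature of 1H-pyrrol-2-yl separates compound 2 from compounds 3 and 4 stays open. So does the outcome of a phenylamino group at this carbon, or of an amine or a carboxylic acid on the phenoxy ring.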